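The source may hold more compounds than are shown below. What is called first, only, known or untested is meant among the compounds shown, and "the series" means these compounds.

Of the compounds shown here, two from this series have been measured in a functional assay on MCF7 cells (Homo sapiens) for antiproliferative activity, read by MTT assay, with a stated time of 48 h; on this read-out higher numbers stand for weaker inhibition and lower numbers for stronger inhibition. Compound 1 `CC(=O)OC/C1=C/C[C@](C)(CCC=C(C)C)/C=C/[C@@H](OC(=O)C=C(C)C)[C@](C)(OC(C)=O)/C=C/C1=O` gives 3990 nM in this assay. Compound 2 `CC(C)=CCC[C@]1(C)/C=C/[C@@H](OC(=O)C=C(C)C)[C@](C)(O)/C=C/C(=O)/C(CN2CCCC2)=C\C1` gives 220 nM in this assay, the lowest of the two numbers; the gap to compound 1 lies beyond the usual scatter of repeat measurements, so compound 2 is the stronger inhibitor of the pair. Among the measured compounds shown here, no two measured compounds differ in only one place, so no single measured step shows how one change moves the read-out.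

Compound 3 `CC(C)=CCC[C@]1(C)/C=C/[C@@H](OC(=O)C=C(C)C)[C@](C)(O)/C=C/C(=O)/C(C(=O)N2CCCC2)=C\C1` has not yet been measured. It differs from compound 2 in one place: (pyrrolidin-1-yl)carbonyl in place of (pyrrolidin-1-yl)methyl on a double-bonded ring carbon. The group that leaves is a (pyrrolidin-1-yl)methyl; the group that enters is a (pyrrolidin-1-yl)carbonyl, which carries a double bond outside aromatic rings. Nothing measured here shows how this assay answers such a swap. The step of a 2.3-fold higher number from compound 2 to compound 3 (0.36 log units; beyond the scatter) is expected to be modest, toward a higher number, with a fair chance that it stays within the scatter. Compound 3 is estimated at 500 nM, with a range from 150 nM to 2000 nM.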

Compound 3, half-maximal inhibitory concentration: 17200 nM
For compound 3 the middle estimate is 34-fold (1.54 log units) below the measured one; the measured number lies above the stated range.
By their numbers in this assay, from the lowest: compound 2; then compound 1; then compound 3.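

In this assay, among the compounds shown here, the swap of (pyrrolidin-1-yl)methyl for (pyrrolidin-1-yl)carbonyl on the double-bonded ring carbon brings a 78-fold higher number from compound 2 to compound 3 (1.89 log units; beyond the scatter) and gives the first single-place step, showing that the read-out is highly sensitive to the group at this position. The two groups share the five-membered ring with its nitrogen and have the same counts of hydrogen-bond donors and acceptors, yet the change in the link between that ring and the core, with its added oxygen and double bond, removes most of the inhibition seen with compound 2. No measurement at hand explains why this link matters so much.

The compounds shown leave open whether other amines joined through the same methyl link, such as a morpholine or a dimethylamino group, would keep the stronger inhibition of compound 2. On these data alone, it also remains open how a simple hydroxymethyl group at this ring carbon would read, and so how much of the inhibition depends on having the pyrrolidine there at all.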